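Chloro for Fluoro on the Aniline of Compound 2

The source may report more compounds than this note shows. Statements on the series, on what has been measured and on what is new or still open speak of the compounds shown alone.

Measured compounds:
Compound 1 `FC(F)(F)c1ccc(CSc2nc(Nc3ccccc3C(F)(F)F)c3ccccc3n2)cc1`: > 50000 nM (a limit)
Compound 2 `Fc1ccc(Nc2nc(SCc3ccc(C(F)(F)F)cc3)nc3ccccc23)cc1`: 19500 nM

In a functional assay on HGC-27 cells (Homo sapiens) for cytotoxicity, read by MTT assay, with a stated time of 72 h (a lower number here means a stronger inhibitor, a higher number a weaker inhibitor), compound 1 gives no number, only a limit, > 50000 nM. Compound 2 gives 19500 nM. For the measured compounds named here, the only measured step runs an at least 2.5-fold lower number from compound 1 to compound 2 (0.40 log units; beyond the scatter), and it tells how far the limit and the number lie apart. Going by the values given here, compound 2 thus holds the only real number among the two values, the other being (the limit of > 50000 nM in this assay, at which 1 of the 2 values shown sits).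

Compound 3 `FC(F)(F)c1ccc(CSc2nc(Nc3ccc(Cl)cc3)c3ccccc3n2)cc1` differs from compound 2 in one place: chloro in place of fluoro on an aromatic carbon. Among the compounds with values here, no measured step covers this kind of swap; the step from compound 1 to compound 2 exchanged one whole aryl group on the nitrogen for another, which is a larger change than exchanging one halogen for another on the same ring. With no direct guide, the step is expected to stay small, most likely within the usual scatter, with a slight lean toward a lower number, so that compound 3 is expected to show a 1.5-fold lower number from compound 2 to compound 3 (0.18 log units; within the scatter). Compound 3 is therefore estimated at 13000 nM, between 4500 nM and 40000 nM.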

Compound 3, half-maximal inhibitory concentration: 14100 nM
The estimate for compound 3 lay 1.1-fold (0.04 log units) below the measured number, and the stated range covers the measured number.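

In this assay, the halogen on this aromatic carbon, para to a large group, can be exchanged without a readable effect: chloro in place of fluoro gives a 1.4-fold lower number from compound 2 to compound 3 (0.14 log units; within the scatter), so the two halogens cannot be told apart here. Placing 4-chlorophenyl instead of 2-(trifluoromethyl)phenyl on the nitrogen gives an at least 3.5-fold lower number from compound 1 to compound 3 (0.54 log units; beyond the scatter), which shows that the earlier gain over compound 1 is not tied to fluoro alone, as two different halogen-bearing phenyl groups now share it. The true size of both gains from compound 1 remains unknown because that compound has only a limit, not a number: the limit of > 50000 nM in this assay, at which 1 of the 3 values shown sits.

Fluoro and chloro are the only groups shown at this position, so it remains open whether a methoxy group, a nitrile or an amine there would shift the number beyond the scatter. Also open is whether the gap from compound 1 comes from the trifluoromethyl group itself or from where it sits on the ring, as the compounds shown include no 4-(trifluoromethyl)phenyl group on that nitrogen.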